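The source may hold more compounds than are shown below. What is called first, only, known or untested is meant among the compounds shown, and "the series" means these compounds.

Notes on the series. All three compounds share one core and differ only in the chain attached at an aromatic carbon. Compound 1 is `CC(C)(C)c1cn(Cc2cc(=O)oc3cc(O)ccc23)nn1`. In a functional assay on SW-620 cells (Homo sapiens) for inhibition, read by MTT assay, with a stated time of 72 h (on this read-out higher numbers stand for weaker inhibition and lower numbers for stronger inhibition), compound 1 gives only a limit, > 100000 nM. Compound 2 is `CCCCCCc1cn(Cc2cc(=O)oc3cc(O)ccc23)nn1`. In this assay compound 2 also gives only a limit, > 100000 nM. Among the measured compounds shown here, the single measured step, a step that the two limits leave unreadable from compound 1 to compound 2, hexyl in place of tert-butyl on an aromatic carbon, therefore has no readable size; both ends sit at the same limit, as summarised by the limit of > 100000 nM in this assay, at which 2 of the 2 values shown sit. Compound 2 thus stands at the limit of this assay and at no number.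

Compound 3 is `CCCCCCCCc1cn(Cc2cc(=O)oc3cc(O)ccc23)nn1`. It differs from compound 2 by ethyl in place of hydrogen on a saturated chain carbon, six bonds along the chain from an aromatic carbon, so the hexyl chain of compound 2 becomes octyl. For the measured compounds named here, the only measured step bears on this change, but it is unreadable, so no direction can be taken from it. The expected step that the limit leaves unreadable from compound 2 to compound 3 is accordingly nothing beyond scatter around the limit. Compound 3 is expected to give 120000 nM in this assay, most likely reported as a further limit.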

Compound 3, half-maximal inhibitory concentration: 50900 nM
Compound 3: middle estimate off by 2.4-fold (0.37 log units), on the high side, and the stated range covers the measured number.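

In this assay, the chain on this aromatic carbon can now be seen to reach a measurable number, and compound 3 is the only compound shown that gives a number rather than a limit: the limit of > 100000 nM in this assay, at which 2 of the 3 values shown sit.
Ethyl in place of hydrogen on a saturated chain carbon, six bonds along the chain from an aromatic carbon, gives an at least 1.9-fold lower number from compound 2 to compound 3 (0.29 log units; that floor lies within the scatter), and exchanging the tert-butyl group for an octyl chain gives an at least 1.9-fold lower number from compound 1 to compound 3 (0.29 log units; that floor lies within the scatter). Going by these compounds, both figures are only floors set by a limit at the starting end, so the true size of each step remains unknown, and the step between the two compounds that sit at the limit cannot be read.

Among the compounds shown here, whether a longer chain, such as decyl, would give a lower number than compound 3 remains open, as the series holds only one number to build on. Also open, on these data alone, is whether the chain must stay purely carbon, since an amine or a carboxylic acid at its far end could give a quite different reading in this assay.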